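A Longer Chain on Compound 1

This account rests on a few compounds, and the source may have more. Where it says the series, first, only, none or still open, it means among the compounds named here.

Three compounds share one core and differ only in the ring on the thiocarbonyl carbon. In a functional assay on MDA-MB-231 cells (Homo sapiens) for inhibition, read by MTT assay, with stated times of 18 h and 4 h (a lower number here means a stronger inhibitor, a higher number a weaker inhibitor), compound 1 `CCCCCCCCOP(=O)(O)OCCSC(=S)N1CCCC1` gives 69000 nM. Compound 2 `CCCCCCCCOP(=O)(O)OCCSC(=S)N1CCCCC1` gives 11900 nM. Compound 3 `CCCCCCCCOP(=O)(O)OCCSC(=S)N1CCCCCC1` gives 27000 nM. Compound 1 therefore has the highest number of the three and is the weakest inhibitor among them.

Compound 4 `CCCCCCCCCCCCCCCCOP(=O)(O)OCCSC(=S)N1CCCC1` keeps the ring of compound 1 and alters the chain instead. The change is octyl in place of hydrogen on a saturated chain carbon, eight bonds along the chain from an oxygen on an unsaturated carbon.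

Among the compounds with values here, no measured step touches the chain, so none bears on this change directly. The ring steps give only a sense of scale, and all three are modest: a 5.8-fold lower number from compound 1 to compound 2 (0.76 log units; beyond the scatter), a 2.6-fold lower number from compound 1 to compound 3 (0.41 log units; beyond the scatter) and a 2.3-fold higher number from compound 2 to compound 3 (0.36 log units; beyond the scatter). Going by these compounds, the direction is untested by any measured pair. Still, compound 1 starts from the top of the series at 69000 nM, so a modest move towards a lower number seems the likelier outcome, with a wide margin for doubt. For compound 4 the expected change is a 2.8-fold lower number from compound 1 to compound 4 (0.44 log units; beyond the scatter), similar in size to the ring steps. The estimate for compound 4 is 25000 nM, with an expected range from 7000 nM to 80000 nM.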

Compound 4, half-maximal inhibitory concentration: 69000 nM
Beside the measured number, compound 4's estimate is 2.8-fold (0.44 log units) below it; low and high end bracket the measured number.
By their numbers in this assay, from the lowest: compound 2; then compound 3; then compounds 1 and 4 (each within the scatter of the next).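

In this assay, octyl in place of hydrogen on a saturated chain carbon, eight bonds along the chain from an oxygen on an unsaturated carbon, gives no change at the digits printed from compound 1 to compound 4 (within the scatter). Within the data shown here, this is the first reading at the chain rather than at the ring on the thiocarbonyl carbon, and with the pyrrolidin-1-yl ring of compound 1 in place, this added octyl leaves no difference in the number, whereas a ring change gives a 5.8-fold lower number from compound 1 to compound 2 (0.76 log units; beyond the scatter). No supporting measurement on hand accounts for this flat result, so it stands as an observation on this one pair.

The compounds shown leave open whether the same octyl change would also make no difference with the rings of compound 2 or compound 3, which start from lower numbers than compound 1. They also leave open whether an amine or a carboxylic acid in place of octyl at this same place on the chain would shift the number in this assay.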